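Adding a Second Fluorine to a Fluorinated Alcohol

The source may report more compounds than this note shows. Statements on the series, on what has been measured and on what is new or still open speak of the compounds shown alone.

Three small fluorinated alcohols have been measured in a physicochemical assay for lipophilicity, read by NMR; a higher number here means a more lipophilic compound, a lower number a more polar compound. Compound 1, `CCCC(O)CF`, carries a single fluorine on its chain, and in this assay compound 1 gives 0.74. Compound 3, `CCCC(O)C(F)F`, is its close relative: the only difference is fluoro in place of hydrogen on a saturated chain carbon bound to a fluorine atom and a saturated chain carbon. In this assay compound 3 gives 1.14, so the change produced a number 0.40 log units higher from compound 1 to compound 3 (beyond the scatter). Compound 2, `OCCC(F)CC(F)(F)F`, belongs to a different core; how its core differs from that of compound 1 is not broken down here. In this assay compound 2 gives 0.84, which sits within the scatter of compound 1 and also within the scatter of compound 3.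

Compound 4, `OCCC(F)(F)CC(F)(F)F`, has not been measured. Its relation to compound 2 is fluoro in place of hydrogen on a saturated chain carbon bound to a fluorine atom and two saturated chain carbons. Among the compounds with values here, that is the same kind of change as the one from compound 1 to compound 3, though not the same: in the earlier pair the carbon that takes the fluorine is bound to a fluorine atom and a saturated chain carbon, whereas here it is bound to a fluorine atom and two saturated chain carbons. Because the earlier change gave a number 0.40 log units higher from compound 1 to compound 3 (beyond the scatter), a step of about a number 0.36 log units higher from compound 2 to compound 4 (beyond the scatter) is expected from the same kind of change in this assay, and compound 4 is therefore estimated at 1.2, most likely between 0.9 and 1.5.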

Compound 4, partition coefficient: 1.12
The estimate for compound 4 lay 0.08 log units above the measured number, within the range that was stated.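

Carried to the core of compound 2, the change gives a number 0.28 log units higher from compound 2 to compound 4 (within the scatter) in this assay, while on the core of compound 1 it gave a number 0.40 log units higher from compound 1 to compound 3 (beyond the scatter). The printed steps therefore point the same way on both cores, but only the first step is beyond the scatter, so the new pair gives weak support for the change carrying over and, taken alone, cannot be told apart from the spread of repeated measurements. This does not show that the change acts alike on the two cores or that it fails on the second, since each core offers a single pair, the carbon taking the fluorine has different neighbours in the two pairs, and no measurement shown here bears on what lies behind either step.

The compounds shown leave open how the same change would behave on a longer chain, or on a core carrying an amine or a carboxylic acid in place of the alcohol. They also leave open whether a further matched pair would settle if the step seen on the core of compound 2 is a real one, as two pairs are too few to establish a rule for this series.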